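Para substituents in the series: from fluoro to benzyloxy

The source may hold more compounds than are shown below. What is called first, only, known or untested is meant among the compounds shown, and "the series" means these compounds.

Measured in a functional assay on the whole organism for inhibition, with Felis catus as the target, with a stated time of 30 min; on this read-out higher numbers stand for an effect only at larger amounts of compound and lower numbers for an effect already at smaller amounts:
compound 1 `OC(CNCCOc1ccccc1)COc1ccccc1` gives 0.054 mg/kg
compound 2 `OC(CNCCOc1ccc(Cl)cc1)COc1ccccc1` gives 0.08 mg/kg
compound 3 `OC(CNCCOc1ccc(F)cc1)COc1ccccc1` gives 0.029 mg/kg

Compound 3, at 0.029 mg/kg, stands apart from only one of the other two compounds. The gap to compound 2 is real but modest, a 2.8-fold lower number from compound 2 to compound 3 (0.44 log units; beyond the scatter), whereas compound 1 cannot be separated from it, a 1.9-fold lower number from compound 1 to compound 3 (0.27 log units; within the scatter).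

The next compound is compound 4 `OC(CNCCOc1ccc(OCc2ccccc2)cc1)COc1ccccc1`, with benzyloxy in place of fluoro on an aromatic carbon, para to a large group (benzyloxy in place of fluoro on an aromatic carbon).

Going by the values given here, three measured steps bear on this position. Adding a halogen to compound 1 changes little in either case: a 1.5-fold higher number from compound 1 to compound 2 (0.17 log units; within the scatter) and a 1.9-fold lower number from compound 1 to compound 3 (0.27 log units; within the scatter). Among the compounds with values here, the one step beyond the scatter, a 2.8-fold lower number from compound 2 to compound 3 (0.44 log units; beyond the scatter), shows that compound 3 has the lower number of this pair, so replacing its fluoro is expected to move the number upward, if it moves at all. None of these steps places a group of this size, or a further ring, at this position, so the data give only weak guidance and the range must stay wide.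

The expected change is small, a 2.4-fold higher number from compound 3 to compound 4 (0.38 log units; beyond the scatter). The estimate for compound 4 is 0.07 mg/kg, with an expected range of 0.02 mg/kg to 0.25 mg/kg.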

Compound 4, dose for half-maximal effect: 0.534 mg/kg
Compound 4: middle estimate off by 7.6-fold (0.88 log units), on the low side; the whole stated range lies below it.
By their numbers in this assay, from the lowest: compounds 3, 1 and 2 (each within the scatter of the next, the first and the last beyond it); then compound 4.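

In this assay, this position on the aromatic ring accepts hydrogen, chloro and fluoro with only small or modest steps, but it does not accept every replacement so readily. Benzyloxy, which brings 8 heavy atoms, a six-membered aromatic ring of carbon only and a hydrogen-bond acceptor, separates compound 4 from all three earlier compounds, with a large step from the fluoro compound (an 18-fold higher number from compound 3 to compound 4 (1.27 log units; beyond the scatter)) and modest ones from the chloro compound (a 6.7-fold higher number from compound 2 to compound 4 (0.82 log units; beyond the scatter)) and the unsubstituted compound (a 9.9-fold higher number from compound 1 to compound 4 (1.00 log units; beyond the scatter)). The order among the smaller groups therefore does not extend to this larger one, as all three steps run in the same direction and each is beyond the scatter, so compound 4 has the highest number of the four.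

Methoxy at the same position would test the ether oxygen without the further ring, and benzyl would test the ring without that oxygen, so the part of benzyloxy that carries the step stays open. Also open, as far as these compounds go, is how an amine or a carboxylic acid on this carbon would read out, and whether a longer chain ending in phenyl would give a step of similar size.

No measurement at hand accounts for this step.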